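This account rests on a few compounds, and the source may have more. Where it says the series, first, only, none or still open, it means among the compounds named here.

Compound 1 `COc1cc(C(=O)/C=C/c2cc(O)ccc2O)cc(OC)c1OC`: > 100000 nM (a limit)
Compound 2 `COc1cc(C(=O)/C=C/c2ccc(O)c(O)c2)cc(OC)c1OC`: 19800 nM

Within the data shown here, in a functional assay on COLO 205 cells (Homo sapiens) for inhibition, read by MTT assay, with a stated time of 48 h (a higher number here means a weaker inhibitor, a lower number a stronger inhibitor), compound 2 gives 19800 nM, the only actual number so far. Compound 1 stands at > 100000 nM, which is a limit and not a number. Compound 3 `COc1cc(C(=O)/C=C/c2cccc(O)c2)cc(OC)c1OC` differs from compound 2 by hydrogen in place of hydroxy on an aromatic carbon, turning 3,4-dihydroxyphenyl into 3-hydroxyphenyl. Among the measured compounds shown here, the one measured step that bears on this is an at least 5.0-fold lower number from compound 1 to compound 2 (0.70 log units; beyond the scatter), which shows that the number responds to where the hydroxy groups sit. For the measured compounds named here, no measured step removes a hydroxy group, so the guide is weak, but a modest change towards a higher number is expected. The expected size is a 1.8-fold higher number from compound 2 to compound 3 (0.25 log units; within the scatter). For compound 3 the estimate is 35000 nM, with an expected range of 12000 nM to 100000 nM.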

Compound 3, half-maximal inhibitory concentration: 49000 nM
Compound 3: middle estimate off by 1.4-fold (0.15 log units), on the low side; the measured number falls inside the stated range.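

In this assay, taking off the hydroxy group para to a large group gives a 2.5-fold higher number from compound 2 to compound 3 (0.39 log units; beyond the scatter), so this position bears on the number, and a modest loss follows from the change to 3-hydroxyphenyl. Set against the 2,5-dihydroxyphenyl analogue, the result is an at least 2.0-fold lower number from compound 1 to compound 3 (0.30 log units; that floor lies within the scatter), and that floor lies within the scatter, so it sets no order on its own. Compound 1 stands at a limit and not a number, so the true size of this step stays open: the limit of > 100000 nM in this assay, at which 1 of the 3 values shown sits.

As far as these compounds go, whether a methoxy group or an amine on this carbon would give a lower number than hydroxy remains open, as does how 4-hydroxyphenyl alone would compare.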